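The source may hold more compounds than are shown below. What is called first, only, known or untested is meant among the compounds shown, and "the series" means these compounds.

Compounds measured in a functional assay for inhibition of sodium/hydrogen exchanger (Oryctolagus cuniculus); on this read-out higher numbers stand for weaker inhibition and lower numbers for stronger inhibition:
compound 1 `Cc1cc(F)c(S(C)(=O)=O)cc1C(=O)N=C(N)N`: 44 nM
compound 2 `Cc1cc(SC(C)(C)C)c(S(C)(=O)=O)cc1C(=O)N=C(N)N`: 22 nM
compound 3 `Cc1cc(Sc2cccc(Cl)c2)c(S(C)(=O)=O)cc1C(=O)N=C(N)N`: 37 nM

Compound 3 stands second highest of these three numbers. The step of a 1.2-fold lower number from compound 1 to compound 3 (0.08 log units; within the scatter) and the step of a 1.7-fold higher number from compound 2 to compound 3 (0.23 log units; within the scatter) both lie within the scatter, so the three compounds are not separated on this read-out. Compound 4 `Cc1cc(O)c(S(C)(=O)=O)cc1C(=O)N=C(N)N` differs from compound 3 in one place: hydroxy in place of (3-chlorophenyl)sulfanyl on an aromatic carbon. The measured steps that bear on this position are a 2.0-fold lower number from compound 1 to compound 2 (0.30 log units; within the scatter) and a 1.2-fold lower number from compound 1 to compound 3 (0.08 log units; within the scatter), each within the scatter; a small group and two large groups at this carbon give the same read. No step beyond the scatter is therefore expected in this assay, and the expected step is a 1.1-fold higher number from compound 3 to compound 4 (0.03 log units; within the scatter). Compound 4 is estimated at 40 nM, with a range from 15 nM to 110 nM.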

Compound 4, half-maximal inhibitory concentration: 220 nM
Compound 4: the middle estimate sits 5.5-fold (0.74 log units) below what was measured, outside the stated range (above it).
By their numbers in this assay, from the lowest: compounds 2, 3 and 1 (each within the scatter of the next); then compound 4.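

In this assay this aromatic carbon does not accept every group: hydroxy gives a 5.9-fold higher number from compound 3 to compound 4 (0.77 log units; beyond the scatter) and a 10-fold higher number from compound 2 to compound 4 (1.00 log units; beyond the scatter) and a 5.0-fold higher number from compound 1 to compound 4 (0.70 log units; beyond the scatter) while fluoro, (tert-butyl)sulfanyl and (3-chlorophenyl)sulfanyl remain within the scatter of one another. Size alone does not sort these compounds, as the small fluoro and hydroxy groups are separated. Nothing available explains the loss with hydroxy.

Going by these compounds, whether the hydrogen-bond donor of hydroxy matters remains open. A methoxy or an amine at this carbon could read with either hydroxy or the other three groups.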